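Swapping the Phenol Ring for a Fluorinated Ring

The compounds below may be only part of what the source reports. "The series", "measured", "known", "first", "only" and "open" are said of these compounds alone.

Measured so far:
Compound 1, `COc1cc(/C=C(/Sc2ccc(Br)cc2)C(=O)c2ccc(Br)cc2)ccc1O`: 1000 nM
Compound 2, `O=C(/C(=C\c1ccc(Cl)cc1)SCc1ccc(Cl)cc1)c1ccc(Br)cc1`: 10000 nM

Both compounds were tested in a functional assay on DU-145 cells (Homo sapiens) for inhibition, read by trypan blue exclusion, with a stated time of 96 h; on this read-out higher numbers stand for weaker inhibition of growth and lower numbers for stronger inhibition of growth. Compound 1 gives 1000 nM, the lowest of the two numbers. Compound 2 gives 10000 nM, a higher number that lies beyond the usual scatter. These two compounds differ in more than one place, so the gap between them cannot be tied to any single change.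

Compound 3, `COc1ccc(/C=C(/Sc2ccc(Br)cc2)C(=O)c2ccc(Br)cc2)c(F)c1`, has not yet been measured. It differs from compound 1 in one place: 2-fluoro-4-methoxyphenyl in place of 4-hydroxy-3-methoxyphenyl on a double-bonded chain carbon bound to a double-bonded chain carbon. In this exchange the hydrogen-bond donor of compound 1 is lost. Within the data shown here, no measured pair shows what this exact exchange does. Compound 3 is expected to give a somewhat higher number than compound 1 in this assay, a step of a 2.5-fold higher number from compound 1 to compound 3 (0.40 log units; beyond the scatter), probably close to the edge of the scatter. Compound 3 is estimated at 2500 nM, with an expected range from 800 nM to 8000 nM.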

Compound 3, concentration for 50% growth inhibition: 20000 nM
Beside the measured number, compound 3's estimate is 8.0-fold (0.90 log units) below it; measured number above the stated range.
By their numbers in this assay, from the lowest: compound 1; then compounds 2 and 3 (each within the scatter of the next).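

In this assay, among these compounds, putting 2-fluoro-4-methoxyphenyl in place of 4-hydroxy-3-methoxyphenyl on a double-bonded chain carbon bound to a double-bonded chain carbon gives a 20-fold higher number from compound 1 to compound 3 (1.30 log units; beyond the scatter), showing for the first time that growth inhibition depends strongly on the group at this place. The exchange is not a single clean edit, however: the hydrogen-bond donor goes, a fluorine enters and the methoxy group sits elsewhere on the ring, all in one step. Nothing available explains the rise in the number.

The compounds shown leave open which part of the exchange matters, a question that a plain 4-methoxyphenyl group, with neither hydroxy nor fluorine, could help to narrow. Also open, going by these compounds, is whether an amine in place of the hydroxy group would keep the stronger inhibition of compound 1.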